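The source may report more compounds than this note shows. Statements on the series, on what has been measured and on what is new or still open speak of the compounds shown alone.

Compound 1 `COc1ccc(OC)c(/C=C/C(=O)Nc2cc3c(Nc4ccc(F)c(Cl)c4)ncnc3cc2O[C@H]2CCOC2)c1`: 26800 nM
Compound 2 `O=C(/C=C/c1ccc(Br)cc1)Nc1cc2c(Nc3ccc(F)c(Cl)c3)ncnc2cc1O[C@H]1CCOC1`: 27500 nM
Compound 3 `COc1ccc(/C=C/C(=O)Nc2cc3c(Nc4ccc(F)c(Cl)c4)ncnc3cc2OC)cc1`: "not determined" (no result reported)

In a functional assay on HeLa cells (Homo sapiens) for cytotoxicity, read by MTT assay, with a stated time of 72 h (a lower number here means a stronger inhibitor, a higher number a weaker inhibitor), compound 1 gives 26800 nM and compound 2 gives 27500 nM; the step of a 1.0-fold higher number from compound 1 to compound 2 (0.01 log units; within the scatter) is within the scatter. Compound 3 stands without a number in this assay, so its own position is not known from the data. The step to compound 4 `COc1ccc(/C=C/C(=O)Nc2cc3c(Nc4ccc(F)c(Cl)c4)ncnc3cc2O[C@H]2CCOC2)cc1` changes only the group on the oxygen on the aromatic ring: oxolan-3-yl in place of methyl on an oxygen on an aromatic ring. Going by the values given here, no measured pair shows the same change, since the only measured step, a 1.0-fold higher number from compound 1 to compound 2 (0.01 log units; within the scatter), concerns the group on the double-bonded chain carbon and not the oxygen. What is known is that compound 4 carries the same oxolan-3-yl on that oxygen as compound 1 and compound 2, and that these two gave values within the scatter of one another in this assay despite different groups on the chain. Compound 4 is therefore expected to fall near them, estimated at 27000 nM, within 10000 nM to 70000 nM.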

Compound 4, half-maximal inhibitory concentration: 34600 nM
The estimate for compound 4 lay 1.3-fold (0.11 log units) below the measured number, within the range that was stated.
By their numbers in this assay, from the lowest: compounds 1, 2 and 4 (each within the scatter of the next).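

Compound 3 has no number in this assay and so the step from compound 3 to compound 4, methyl to oxolan-3-yl on an oxygen on an aromatic ring, cannot be read. What compound 4 does add comes from the chain side with (oxolan-3-yl)oxy held constant: there is a 1.3-fold higher number from compound 2 to compound 4 (0.10 log units; within the scatter) with methoxy in place of bromo on an aromatic carbon, and a 1.3-fold higher number from compound 1 to compound 4 (0.11 log units; within the scatter) with 4-methoxyphenyl in place of 2,5-dimethoxyphenyl, so all three compounds now sit within the scatter of one another. Nothing available explains why these values sit together.

On these data alone, whether methoxy on that oxygen gives a value like those of the oxolan-3-yl compounds remains open. So does whether an amine or a carboxylic acid on the aromatic ring would move the number at all.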